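The compounds below may be only part of what the source reports. "The series", "measured", "known", "first", "only" and "open" are said of these compounds alone.

Among the compounds with values here, the account starts from compound 2 `O=c1cc(C2CCCC2)oc2ccc(OCCCCCCN3CCC(O)CC3)cc12`, which in an assay on isolated protein (Cavia porcellus) with Sigma non-opioid intracellular receptor 1 (Homo sapiens) as the target, read by radioligand binding (on this read-out higher numbers stand for weaker inhibition and lower numbers for stronger inhibition), gives 55 nM and stands second highest of the three numbers so far: compound 3 `O=c1cc(C2CCCCC2)oc2ccc(OCCCCCCN3CCC(O)CC3)cc12` gives 46 nM and compound 1 `COc1cccc(-c2cc(=O)c3cc(OCCCCCCN4CCC(O)CC4)ccc3o2)c1` gives 111 nM. The steps measured so far all concern the group on the aromatic carbon: a 2.0-fold lower number from compound 1 to compound 2 (0.30 log units; within the scatter), a 2.4-fold lower number from compound 1 to compound 3 (0.38 log units; beyond the scatter) and a 1.2-fold lower number from compound 2 to compound 3 (0.08 log units; within the scatter). Compound 4 `O=c1cc(C2CCCC2)oc2ccc(OCCCCCCN3CCCCC3)cc12` changes a different place, the ring at the end of the chain: hydrogen in place of hydroxy on a saturated ring carbon. Within the data shown here, no measured pair touches that ring, so none of the measured steps bears directly on this change; they only show that the end of the molecule studied so far tolerates variation without large movement. Among the measured compounds shown here, with no direct precedent, the step is expected to be at most modest, and the guess leans toward a somewhat lower number for compound 4. The step from compound 2 to compound 4 is estimated as a 1.6-fold lower number from compound 2 to compound 4 (0.20 log units; within the scatter) in this assay. Compound 4 is thus expected to give about 35 nM in this assay, with a range from 12 nM to 110 nM.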

Compound 4, half-maximal inhibitory concentration: 38 nM
Compound 4: middle estimate off by 1.1-fold (0.04 log units), on the low side, and the stated range covers the measured number.
By their numbers in this assay, from the lowest: compounds 4, 3, 2 and 1 (each within the scatter of the next, the first and the last beyond it).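

In this assay the ring at the end of the chain now has a measured step of its own: on the saturated ring carbon three ring bonds from the ring nitrogen, hydrogen in place of hydroxy gives a 1.4-fold lower number from compound 2 to compound 4 (0.16 log units; within the scatter) and so stays within the usual scatter. In this one pair, with cyclopentyl held constant, the 4-hydroxypiperidin-1-yl and piperidin-1-yl ends cannot be told apart, even though one hydrogen-bond donor and one acceptor leave with the hydroxy. No measurement is at hand that would explain this result.

The compounds shown leave open whether the same change behaves alike when cyclohexyl or 3-methoxyphenyl sits on the aromatic carbon. They also leave open what a methoxy group, an amine or a carboxylic acid would do on that ring carbon, and what a shorter or longer chain would do.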